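Replacing 3-methoxyphenyl with methyl on the ester chain

The source may hold more compounds than are shown below. What is called first, only, known or untested is meant among the compounds shown, and "the series" means these compounds.

In an ADME assay on HepG2 2.2.15 cells (Homo sapiens) for cytotoxicity (a lower number here means that less compound is tolerated, a higher number that more compound is tolerated), compound 1 `O=C(OCCc1c(-c2ccccc2Cl)c2cc(Cl)ccc2[nH]c1=O)c1cccnc1` gives 170000 nM. Compound 2 `COc1cccc(/C=C/C(=O)OCCc2c(-c3ccccc3Cl)c3cc(Cl)ccc3[nH]c2=O)c1` gives > 1300000 nM, which is a limit of the assay and not a number. Compound 3 `C/C=C/C(=O)OCCc1c(-c2ccccc2Cl)c2cc(Cl)ccc2[nH]c1=O` has not been measured and places methyl where compound 2 carries 3-methoxyphenyl: methyl in place of 3-methoxyphenyl on a double-bonded chain carbon bound to a double-bonded chain carbon. Within the data shown here, only one measured step bears on this change, an at least 7.6-fold higher number from compound 1 to compound 2 (0.88 log units; beyond the scatter), and it brought in 2-(3-methoxyphenyl)ethenyl. Losing that aromatic ring should therefore give back part of this gain, so a lower number is expected in this assay. The expected change is an at least 2.8-fold lower number from compound 2 to compound 3 (0.46 log units; beyond the scatter). For compound 3 the estimate is 450000 nM, with an expected range of 130000 nM to 1300000 nM.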

Compound 3, half-maximal cytotoxic concentration: 30000 nM
The estimate for compound 3 lay 15-fold (1.18 log units) above the measured number, outside the stated range (below it).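

In this assay, methyl in place of 3-methoxyphenyl gives an at least 43-fold lower number from compound 2 to compound 3 (1.63 log units; beyond the scatter). The loss does more than undo the earlier gain, since the ethenyl link alone does not hold the number up: prop-1-en-1-yl gives a 5.7-fold lower number from compound 1 to compound 3 (0.75 log units; beyond the scatter). Compound 2 stands at a limit of the assay, not at a number: the limit of > 1300000 nM in this assay, at which 1 of the 3 values shown sits.

From the compounds shown here alone, whether the higher tolerance needs the whole 3-methoxyphenyl group or only its ring stays open, and plain phenyl would separate the two. So does whether a longer chain, such as propyl, in place of methyl would raise the number.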